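This account rests on a few compounds, and the source may have more. Where it says the series, first, only, none or still open, it means among the compounds named here.

Compound 1 `[O-]/[N+](=C\c1cn(-c2ccccc2)nn1)c1ccccc1`: in a functional assay on COLO 205 cells (Homo sapiens) for inhibition, read by MTT assay, with a stated time of 24 h (a lower number here means a stronger inhibitor, a higher number a weaker inhibitor), compound 1 gives > 100000 nM, which is a limit of the assay and not a number.
Compound 2 `CC(C)(C)/[N+]([O-])=C/c1cn(-c2ccccc2)nn1`: in this assay compound 2 gives 15200 nM.

Compound 2 thus holds the only real number shown; the one further value is a limit (the limit of > 100000 nM in this assay, at which 1 of the 2 values shown sits). Among the measured compounds shown here, the single measured step, an at least 6.5-fold lower number from compound 1 to compound 2 (0.81 log units; beyond the scatter), concerns the group on the double-bonded nitrogen and leaves the ring untouched. Compound 3 `CC(C)(C)/[N+]([O-])=C/c1cn(-c2ccc(C(F)(F)F)cc2)nn1` differs from compound 2 by trifluoromethyl in place of hydrogen on an aromatic carbon. No measured step touches that ring, so nothing shown bears directly on this change, and no step beyond the scatter is expected in this assay in either direction. For compound 3 the expected step is a 1.0-fold lower number from compound 2 to compound 3 (0.01 log units; within the scatter), within the usual scatter. Compound 3 is therefore estimated at 15000 nM, with a range from 6000 nM to 40000 nM.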

Compound 3, half-maximal inhibitory concentration: 44700 nM
Compound 3: the middle estimate sits 3.0-fold (0.47 log units) below what was measured; the measured number lies above the stated range.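

The earlier step left the six-membered aromatic ring untouched, and this one shows that the number in this assay responds to a change on that ring, with a 2.9-fold higher number from compound 2 to compound 3 (0.47 log units; beyond the scatter). With tert-butyl held in place on the double-bonded nitrogen, trifluoromethyl on this aromatic carbon, para to a large group, goes with a weaker inhibitor, though the step is modest. Nothing given here bears on why the number rises.

Whether this rise belongs to trifluoromethyl itself stays open, since the compounds shown do not tell what an amine, a carboxylic acid or a single fluorine atom would do at this place. As far as these compounds go, it is also open whether the same change would give a similar step with phenyl on the double-bonded nitrogen in place of tert-butyl.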